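A few compounds are considered here, and "the series" means these few. Any claim that something is new, unique, unknown or untested is made for them only; others in the source may bear on it.

Measured in a functional assay on HL-60 cells (Homo sapiens) for inhibition, read by CCK-8 assay, with a stated time of 48 h; on this read-out lower numbers stand for stronger inhibition and higher numbers for weaker inhibition:
- compound 1 `COc1ccc(NC(=O)NCCNS(=O)(=O)c2sccc2-c2ccc(C)cc2Oc2ccc(O)c(O)c2)cc1`: 6100 nM
- compound 2 `O=C(NCCNS(=O)(=O)c1ccc(-c2ccccc2OCc2ccccc2)s1)Nc1cccc([N+](=O)[O-])c1`: 2800 nM
- compound 3 `O=[N+]([O-])c1cccc(NC(=S)NCCNS(=O)(=O)c2ccc(-c3ccccc3OCc3cccc(O)c3)s2)c1`: 11400 nM

Compound 1 at 6100 nM lies within the scatter of compound 3 at 11400 nM, while compound 2 gives a lower number, 2800 nM, beyond the scatter from compound 1. Compound 4 `Cc1ccc(-c2ccsc2S(=O)(=O)NCCNC(=O)Nc2cc(Cl)cc(Cl)c2)c(Oc2ccc(O)c(O)c2)c1` has 3,5-dichlorophenyl in place of 4-methoxyphenyl on an amide-type nitrogen. For the measured compounds named here, no measured pair isolates a single change, so the data offer no direct guide to its size. A modest move toward a lower number is expected in this assay, possibly no larger than the scatter. The expected change is a 1.6-fold lower number from compound 1 to compound 4 (0.21 log units; within the scatter). Compound 4 is estimated at 3800 nM, with an expected range of 1300 nM to 11000 nM.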

Compound 4, half-maximal inhibitory concentration: 3500 nM
The estimate for compound 4 lay 1.1-fold (0.04 log units) above the measured number; the measured number falls inside the stated range.
By their numbers in this assay, from the lowest: compounds 2, 4, 1 and 3 (each within the scatter of the next, the first and the last beyond it).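

In this assay, for the compounds shown here, the exchange of 4-methoxyphenyl for 3,5-dichlorophenyl on an amide-type nitrogen gives a 1.7-fold lower number from compound 1 to compound 4 (0.24 log units; within the scatter) and is the first change in a single place that can be read. At this position, the two aryl groups cannot be told apart on this read-out, despite their different substituents. Nothing measured here bears on the reason for this result. On these data alone, whether an amine or a carboxylic acid on this phenyl ring, or a longer chain in its place, would shift the number beyond the scatter remains open.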